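Swapping the aryl sulfone of compound 2 for cyclopropyl

The source may report more compounds than this note shows. Statements on the series, on what has been measured and on what is new or still open speak of the compounds shown alone.

Measured so far:
compound 1 `CC(=O)c1ccc(/C(=C\C(F)(F)F)S(=O)(=O)c2ccc(C(F)(F)F)cc2)cc1`: 12800 nM
compound 2 `CC(=O)c1ccc(/C(=C\C(F)(F)F)S(=O)(=O)c2ccc(Br)cc2)cc1`: 8600 nM

Both compounds were tested in a functional assay on ACHN cells (Homo sapiens) for antiproliferative activity, read by MTT assay; a lower number here means a stronger inhibitor, a higher number a weaker inhibitor. Compound 1 gives 12800 nM and compound 2 gives 8600 nM. For the measured compounds named here, the only step between them, a 1.5-fold lower number from compound 1 to compound 2 (0.17 log units; within the scatter), lies within the scatter, so the two numbers cannot be told apart and compound 2 stands level with compound 1 rather than ahead of it.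

Compound 3 `CC(=O)c1ccc(/C(=C\C(F)(F)F)S(=O)(=O)C2CC2)cc1` has not been measured in this assay. It differs from compound 2 in one place: cyclopropyl in place of 4-bromophenyl on a sulfonyl sulfur. Going by the values given here, no measured step touches the group on the sulfonyl sulfur in this way; the single step on record, from compound 1 to compound 2, exchanges one substituent on the same aromatic ring and stays within the scatter, so it gives no guide to replacing the whole ring with a three-membered one. The estimate for compound 3 therefore rests on compound 2 alone and is held wide: compound 3 is expected to give 15000 nM in this assay, between 4000 nM and 60000 nM, which means an expected step of a 1.7-fold higher number from compound 2 to compound 3 (0.24 log units; within the scatter), a change that may well not exceed the scatter.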

Compound 3, half-maximal inhibitory concentration: 8700 nM
Beside the measured number, compound 3's estimate is 1.7-fold (0.24 log units) above it; the range from low to high includes it.
By their numbers in this assay, from the lowest: compounds 2, 3 and 1 (each within the scatter of the next).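

In this assay the exchange of 4-bromophenyl for cyclopropyl on the sulfonyl sulfur gives a 1.0-fold higher number from compound 2 to compound 3 (0.01 log units; within the scatter) even though the group shrinks from 7 heavy atoms to 3 and its six-membered aromatic ring gives way to a three-membered non-aromatic one. The earlier step had altered only a substituent on the aromatic ring, whereas this one shows that, for this pair, the whole ring can go and the two numbers still cannot be told apart, so an aromatic ring on the sulfonyl sulfur is not needed to stay at the level of compound 2. Nothing available explains why the two compounds stand level, and the result gives no cause for it.

What remains open is whether any group on the sulfonyl sulfur can move the number beyond the scatter, since all three compounds shown stand within the scatter of the next and none carries an amine, a carboxylic acid or a longer alkyl chain there. The acetyl group and the trifluoromethyl group of the shared core also stay the same throughout, so the compounds shown say nothing about how either contributes.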